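This account rests on a few compounds, and the source may have more. Where it says the series, first, only, none or still open, it means among the compounds named here.

Working notes on the shared core of compound 2 `S=C(SCc1cn(Cc2ccc(Cl)c(Cl)c2)nn1)N1CCNCC1`, read in a functional assay on ECa-109 cells (Homo sapiens) for inhibition, read by MTT assay, with a stated time of 72 h; a higher number here means a weaker inhibitor, a lower number a stronger inhibitor.

Where compound 2 stands: in this assay compound 2 gives > 128000 nM, which is a limit of the assay and not a number. Compound 1 `Fc1ccc(Cn2cc(CSC(=S)N3CCNCC3)nn2)cc1` gives > 128000 nM in this assay, likewise a limit. Compound 3 `CC(C)(C)OC(=O)N1CCN(C(=S)SCc2cn(Cc3ccc(Cl)c(Cl)c3)nn2)CC1` gives > 128000 nM in this assay, also a limit. For the measured compounds named here, two measured steps bear on the aryl position and the ring amine, a step that the two limits leave unreadable from compound 1 to compound 2 and a step that the two limits leave unreadable from compound 2 to compound 3; both are unreadable because of the limit of > 128000 nM in this assay, at which 3 of the 3 values shown sit. Going by the values given here, no measured compound gives a number.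

Compound 4 `COc1ccc(Cn2cc(CSC(=S)N3CCNCC3)nn2)cc1` is not yet measured. It differs from compound 2 by 4-methoxyphenyl in place of 3,4-dichlorophenyl on a saturated chain carbon bound to an aromatic nitrogen. Among the compounds with values here, the one measured change at the same position, a different aryl group, left the read-out at the limit, so the expected step is a step that the limit leaves unreadable from compound 2 to compound 4, none beyond the scatter. Compound 4 is estimated at 200000 nM in this assay, with a range from 100000 nM to 500000 nM, most probably reported again only as a limit.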

Compound 4, half-maximal inhibitory concentration: > 128000 nM
Compound 4: no number, only a limit; the forecaster's own chance of this, stated with the estimate: 85%; the middle value is on the limit's open side.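

The steps to compound 4 from compound 1 and from compound 2 cannot be read, because the read-outs stop at the same limit: the limit of > 128000 nM in this assay, at which 4 of the 4 values shown sit.

The compounds shown leave open whether any change to the shared core yields a number, and how the aryl groups rank.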